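Sigma-1 binding: azepane-linked benzothiazolone series, propylcarbonyl step

The source may hold more compounds than are shown below. What is called first, only, known or untested is meant among the compounds shown, and "the series" means these compounds.

Three compounds of this series have numbers in an assay on cell membranes for displacement of a labelled ligand from Sigma non-opioid intracellular receptor 1 (Rattus norvegicus); a higher number here means a weaker inhibitor, a lower number a stronger inhibitor. Compound 1 `CCCc1ccc2c(c1)sc(=O)n2CCN1CCCCCC1` gives 1.6 nM in this assay. Compound 2 `O=c1sc2ccccc2n1CCCN1CCCCCC1` gives 4.1 nM in this assay. Compound 3 `CCC(=O)c1ccc2c(c1)sc(=O)n2CCCCCN1CCCCCC1` gives 12.2 nM in this assay. Compound 2 thus stands second highest of the three numbers: compound 1 sits beyond the scatter on the lower side, compound 3 beyond the scatter on the higher side, and compound 2 lies between them. Among the compounds with values here, none of the three pairs differs in only one place, so no single-change step is available as a guide.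

Compound 4 `CCCC(=O)c1ccc2c(c1)sc(=O)n2CCCN1CCCCCC1` is not yet measured in this assay. It differs from compound 2 by propylcarbonyl in place of hydrogen on an aromatic carbon. Compound 3, which also carries a carbonyl substituent on the same ring but differs from compound 2 in more than one place, gives the highest number of the three, while compound 1, with a plain chain at that ring position, gives the lowest. On this thin basis no step beyond the scatter is expected from compound 2 to compound 4, with a slight lean toward a higher number. The step from compound 2 to compound 4 is estimated at a 1.3-fold higher number from compound 2 to compound 4 (0.13 log units; within the scatter). Compound 4 is expected to give 5.5 nM in this assay, within 1.8 nM to 17 nM.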

Compound 4, inhibition constant: 2.6 nM
Beside the measured number, compound 4's estimate is 2.1-fold (0.33 log units) above it; measured number inside the range.
By their numbers in this assay, from the lowest: compounds 1, 4 and 2 (each within the scatter of the next, the first and the last beyond it); then compound 3.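

In this assay the series now has its first step that can be read in one place: propylcarbonyl in place of hydrogen on an aromatic carbon gives a 1.6-fold lower number from compound 2 to compound 4 (0.20 log units; within the scatter). This shows that the position, on the six-membered aromatic ring, meta to a fused ring and para to a fused ring, can carry a group of 5 heavy atoms that includes a carbonyl while the number stays within the scatter, which compound 1 and compound 3 could not show, as each differs from compound 2 and compound 4 in more than one place and those steps cannot be read. Nothing in the data shown accounts for this result, and no measurement beyond the binding numbers bears on it.

Still open, on these data alone, is how far this holds for other groups at the same position, such as an amine, a carboxylic acid, a methoxy group or a longer acyl chain. Also open, as far as these compounds go, is whether the carbonyl of the propylcarbonyl group matters at all, a question that a plain propyl group on the core of compound 4 would address in a single change.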